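The source may report more compounds than this note shows. Statements on the series, on what has been measured and on what is new or still open speak of the compounds shown alone.

Among the measured compounds shown here, compound 2, `COc1ccc(-c2ccnc(C(=O)N(C)C)c2)cc1S(=O)(=O)Nc1cccc(NCCNC(=O)c2cccc(C)c2)c1`, is the higher of the two numbers measured so far: in a functional assay on CHO-RD-HGA16 cells for agonist activity at Orexin/Hypocretin receptor type 1 (Homo sapiens), read by fluorescence and calcium flux, with a stated time of 30 min (on this read-out higher numbers stand for larger maximal responses and lower numbers for smaller maximal responses), compound 2 gives 101%, while compound 1, `COc1ccc(-c2cc(C(=O)N(C)C)ccn2)cc1S(=O)(=O)Nc1cccc(NCCNC(=O)c2cccc(C)c2)c1`, gives 93%, and the step of a number 8 percentage points higher from compound 1 to compound 2 (within the scatter) lies within the scatter, so the two compounds cannot be told apart.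

Compound 3, `COc1ccc(-c2cccc(C(=O)N(C)C)n2)cc1S(=O)(=O)Nc1cccc(NCCNC(=O)c2cccc(C)c2)c1`, differs from compound 2 by 6-(dimethylcarbamoyl)pyridin-2-yl in place of 2-(dimethylcarbamoyl)pyridin-4-yl on an aromatic carbon. For the measured compounds named here, the only step measured so far is the one from compound 1 to compound 2, which likewise rearranged the same atoms of this group on the same aromatic carbon and was within the scatter. On that basis a step no larger than the scatter is expected, in either direction, so that compound 3 is estimated at a number 5 percentage points lower from compound 2 to compound 3 (within the scatter). The expected value for compound 3 is 96%, with a range from 80% to 110%.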

Compound 3, largest response reached (Emax), in percent of the reference or control that the assay uses: 100%
Estimate against measurement, compound 3: 4 percentage points below; the measured number falls inside the stated range.
By their numbers in this assay, from the lowest: compounds 1, 3 and 2 (each within the scatter of the next).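

With 6-(dimethylcarbamoyl)pyridin-2-yl as a third arrangement of the same atoms on this aromatic carbon, this assay shows a number 1 percentage points lower from compound 2 to compound 3 (within the scatter) and a number 7 percentage points higher from compound 1 to compound 3 (within the scatter). All three pairs among these isomers can now be compared, and none can be told apart, so rearranging the ring nitrogen and the dimethylcarbamoyl group within this substituent, para to the methoxy group, gives no detectable difference in maximal response among the three arrangements shown. Nothing available explains this result.

On these data alone, all three compounds keep a pyridine ring bearing a dimethylcarbamoyl group, so it remains open how the maximal response would compare with a different group on this carbon, such as a carboxylic acid or a primary amine in place of the dimethylcarbamoyl group. As far as these compounds go, a plain phenyl ring in place of the pyridine is equally open.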